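The source may hold more compounds than are shown below. What is called first, only, known or untested is meant among the compounds shown, and "the series" means these compounds.

Three chalcone-type compounds share one core, a carbonyl-linked pair of aromatic rings with a benzyl ether on one of them. Compound 1 `O=C(/C=C/c1ccccc1Cl)c1ccc(OCc2ccccc2)cc1` carries a chlorine on the far aromatic ring, and in a functional assay on HCT-116 cells (Homo sapiens) for antiproliferative activity, read by sulforhodamine B assay, with a stated time of 3 days, tested at 50 uM (a lower number here means a weaker effect, a higher number a stronger effect of the compound at the concentration tested), compound 1 gives 99.7%. Compound 2 `Cc1ccc(COc2ccc(C(=O)/C=C/c3ccccc3)cc2)cc1` instead carries a methyl on the benzyl ether ring, but for compound 2 this assay gives "not determined" (no result reported), so compound 2 stands without a number of its own and offers no fixed point for comparison.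

Compound 3 `O=C(/C=C/c1ccccc1)c1ccc(OCc2ccccc2)cc1` is the bare parent, reached from compound 2 by the change (hydrogen in place of methyl on an aromatic carbon), that is, hydrogen in place of methyl on an aromatic carbon. Going by the values given here, because compound 2 has no value, the size of this step cannot be read from the data, and no step between measured compounds is known. Without a measured anchor on either side, the step in this assay is expected to be small, within the usual scatter, in no clear direction. For compound 3, an inhibition of 90% is estimated, with a range from 60% to 100%, because compound 1 gives 99.7% at the same concentration.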

Compound 3, a percentage reported as inhibition, at one concentration (the size of the read-out at that concentration, not a potency): 33.8%
Compound 3: the middle estimate sits 56.2 percentage points above what was measured; the measured number lies below the stated range.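

Replacing the chloro group on the far aromatic ring with hydrogen, the only difference between these two structures, gives a number 65.9 percentage points lower from compound 1 to compound 3 (beyond the scatter) in this assay. This shows that the far ring is not a silent place on the shared core: at the single concentration tested, one chloro group separates almost complete inhibition from a much smaller read-out, so the bare parent cannot stand in for its chlorinated relative. Compound 2 has no value, so its step to compound 3 cannot be read, and nothing available explains the size of the chloro-to-hydrogen step.

On these data alone, with only chloro and hydrogen on the far ring, it remains open whether a fluoro, a bromo, a methoxy group or an amine there would keep the high read-out, or whether chloro is special among them. As far as these compounds go, the effect of the methyl group in the 4-methylbenzyl ether also remains unknown, and a read-out at one concentration gives only the size of the effect at that concentration.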